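The source may report more compounds than this note shows. Statements on the series, on what has been measured and on what is new or still open speak of the compounds shown alone.

Measured compounds in a functional assay on MG-63 cells (Homo sapiens) for inhibition, read by CCK-8 assay, with a stated time of 72 h, tested at 1 uM; a higher number here means more inhibition at the concentration tested (going by the name of the read-out), a lower number less inhibition:
compound 1 `COc1ccc(C)cc1N1C(=O)CSC1c1cccc(C(=O)NCCCCc2ccccc2)c1` gives 92%;
compound 2 `COc1cc(F)ccc1N1C(=O)CSC1c1cccc(C(=O)NCCCCc2ccccc2)c1` gives 92%.

Compound 2 stands level with compound 1 at the digits shown; the one measured step, no change at the digits printed from compound 1 to compound 2 (within the scatter), lies within the scatter. Compound 3 `CC(F)(F)c1cccc(N2C(=O)CSC2c2cccc(C(=O)NCCCCc3ccccc3)c2)c1` carries a group of 10 heavy atoms (8 carbon, 2 fluorine; one six-membered aromatic ring of carbon only) in place of a group of 9 heavy atoms (7 carbon, 1 oxygen, 1 fluorine; one six-membered aromatic ring of carbon only), on an amide-type nitrogen in a ring. Within the data shown here, the only step that bears on it is the aryl swap from compound 1 to compound 2, which left the read-out unchanged, so another aryl swap on the same nitrogen is expected to move this assay little: a number 6 percentage points lower from compound 2 to compound 3 (within the scatter). Compound 3 is therefore estimated at 86%, with a range of 65% to 96%.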

Compound 3, a percentage reported as inhibition, at one concentration (the size of the read-out at that concentration, not a potency): 92%
The estimate for compound 3 lay 6 percentage points below the measured number, within the range that was stated.
By their numbers in this assay, from the lowest: compounds 1, 2 and 3 (each within the scatter of the next).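

In this assay, the group of 10 heavy atoms, with 0 hydrogen-bond acceptors, replaces the 4-fluoro-2-methoxyphenyl, with 1 hydrogen-bond acceptor, and the reading is no change at the digits printed from compound 2 to compound 3 (within the scatter). Against the 2-methoxy-5-methylphenyl group the reading is no change at the digits printed from compound 1 to compound 3 (within the scatter), so on this amide-type nitrogen the read-out holds without the methoxy oxygen. No available evidence bears on why it holds.

As far as these compounds go, whether a carboxylic acid, an amine or a cyclohexyl ring at this position would hold the reading remains open. A reading at one concentration also leaves any potency differences among the three compounds unresolved.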